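Methoxy versus dimethylamino on a thiophene and benzofuran nucleoside series

This account rests on a few compounds, and the source may have more. Where it says the series, first, only, none or still open, it means among the compounds named here.

Measured so far:
Compound 1 `COc1ncnc2c1c(-c1cccs1)cn2[C@@H]1O[C@H](CO)[C@@H](O)[C@H]1O`: 440 nM
Compound 2 `CN(C)c1ncnc2c1c(-c1cccs1)cn2[C@@H]1O[C@H](CO)[C@@H](O)[C@H]1O`: > 20000 nM, a limit
Compound 3 `CN(C)c1ncnc2c1c(-c1cc3ccccc3o1)cn2[C@@H]1O[C@H](CO)[C@@H](O)[C@H]1O`: > 20000 nM, a limit

In a functional assay on HCT-116 cells (Homo sapiens), read by MTT assay, with a stated time of 72 h (on this read-out lower numbers stand for stronger inhibition and higher numbers for weaker inhibition), compound 1 gives 440 nM. For compound 2 the assay reports only a limit, > 20000 nM. For compound 3 the assay likewise reports only a limit, > 20000 nM. The change from compound 2 to compound 1 is methoxy in place of dimethylamino on an aromatic carbon, and it made an at least 45-fold lower number from compound 2 to compound 1 (1.65 log units; beyond the scatter). The cores of compound 2 and compound 3 differ by 1-benzofuran-2-yl in place of thiophen-2-yl on an aromatic carbon; the step that the two limits leave unreadable from compound 2 to compound 3 stays unreadable due to the limit of > 20000 nM in this assay, at which 2 of the 3 values shown sit.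

Compound 4 `COc1ncnc2c1c(-c1cc3ccccc3o1)cn2[C@@H]1O[C@H](CO)[C@@H](O)[C@H]1O` is not yet measured. It differs from compound 3 by methoxy in place of dimethylamino on an aromatic carbon, the same change as from compound 2 to compound 1, at the same place. The expected step is an at least 13-fold lower number from compound 3 to compound 4 (1.12 log units; beyond the scatter), an estimate resting on the earlier step of an at least 45-fold lower number from compound 2 to compound 1 (1.65 log units; beyond the scatter), with the starting point a limit so the size remains uncertain. Compound 4 is expected to land near 1500 nM, estimated between 300 nM and 20000 nM.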

Compound 4, half-maximal inhibitory concentration: 14500 nM
For compound 4 the middle estimate is 9.7-fold (0.99 log units) below the measured one; low and high end bracket the measured number.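

Notes on the series: in this assay, methoxy in place of dimethylamino on the core of compound 3 gives an at least 1.3-fold lower number from compound 3 to compound 4 (0.13 log units; that floor lies within the scatter), so this step neither confirms nor excludes a transfer of the large step seen on the thiophen-2-yl core. Set side by side, the two steps do not show whether the change carries over from one core to the other at the same size: the same change on two cores in this assay, an at least 45-fold lower number (1.65 log units; beyond the scatter) from compound 2 to compound 1 and an at least 1.3-fold lower number (0.13 log units; that floor lies within the scatter) from compound 3 to compound 4; the limit leaves it open whether they differ With methoxy held constant, 1-benzofuran-2-yl in place of thiophen-2-yl gives a 33-fold higher number from compound 1 to compound 4 (1.52 log units; beyond the scatter), so the result of this change differs between the methoxy compounds on the two cores, though this single pair shows nothing about other aromatic groups.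

As far as these compounds go, the true size of the methoxy step on either core stays open, since neither dimethylamino compound has a value of its own: the limit of > 20000 nM in this assay, at which 2 of the 4 values shown sit. Also open is how ethoxy, a longer alkoxy chain or a primary amine in place of methoxy would read on either core.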